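Aryl variation on the shared core: lipophilicity notes

The source may report more compounds than this note shows. Statements on the series, on what has been measured and on what is new or still open speak of the compounds shown alone.

Measured so far in a physicochemical assay for lipophilicity, using the shake flask method, in phosphate buffer, measured as octanol-water partition, with a stated time of 85 min, at pH 7.4; a lower number here means a more polar compound, a higher number a more lipophilic compound:
compound 1, `COc1ccc(-c2cn3ccnc3c(-c3ccc4ncn(C5CCCCC5)c4c3)n2)cc1`, 1.41
compound 2, `Fc1ccc(-c2cn3ccnc3c(-c3ccc4ncn(C5CCCCC5)c4c3)n2)cc1`, 2.01
compound 3, `Cc1cccc(-c2cn3ccnc3c(-c3ccc4ncn(C5CCCCC5)c4c3)n2)c1`, not yet measured

Compound 2 stands highest of the two numbers in this assay; its nearest neighbour is compound 1, with a number 0.60 log units higher from compound 1 to compound 2 (beyond the scatter). The step to compound 3 is 3-methylphenyl in place of 4-fluorophenyl on an aromatic carbon. Among the measured compounds shown here, only one measured step exists, and it is of a different kind: a number 0.60 log units higher from compound 1 to compound 2 (beyond the scatter), a modest change beyond the scatter. That step shows the scale at which this position responds to a single exchange on the aryl ring, but it does not cover methyl in place of fluoro, so the expectation for compound 3 is a small move upward or none beyond the scatter. For compound 3 in this assay the expected step is a number 0.29 log units higher from compound 2 to compound 3 (within the scatter), giving an estimate of 2.3 with a range of 1.9 to 2.7.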

Compound 3, partition coefficient: 1.87
Compound 3: middle estimate off by 0.43 log units, on the high side; measured number below the stated range.
By their numbers in this assay, from the lowest: compound 1; then compounds 3 and 2 (each within the scatter of the next).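

In this assay the exchange of 4-fluorophenyl for 3-methylphenyl gives a number 0.14 log units lower from compound 2 to compound 3 (within the scatter) and so does not separate these two aryl groups at this position. The comparison with the methoxy compound gives a number 0.46 log units higher from compound 1 to compound 3 (beyond the scatter) as a modest step, which leaves 4-methoxyphenyl apart from both other aryl groups in this set of three, rather than from 4-fluorophenyl alone. No measured information at hand accounts for these numbers.

Whether 4-methylphenyl would read like 3-methylphenyl stays open, since the compounds shown do not separate the identity of the group from where it sits on the aryl ring. Also open, on these data alone, is how far this position would move with an aryl ring carrying an amine or a carboxylic acid.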